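A few compounds are considered here, and "the series" means these few. Any claim that something is new, unique, unknown or untested is made for them only; others in the source may bear on it.

Working notes on the series. In a functional assay on MCF7 cells (Homo sapiens) for inhibition, read by MTT assay, with a stated time of 48 h (on this read-out higher numbers stand for weaker inhibition and lower numbers for stronger inhibition), compound 1 (`CCOC(=O)C(S/C(=N/NC(=O)COc1ccc2c(-c3ccccc3)cc(=O)oc2c1)NC)C(C)=O`) gives 30.6 ug/mL and compound 2 (`CCN/C(=N\NC(=O)COc1ccc2c(-c3ccccc3)cc(=O)oc2c1)SC(C(C)=O)C(=O)OCC`) gives 41.9 ug/mL. Within the data shown here, the one measured step is a 1.4-fold higher number from compound 1 to compound 2 (0.14 log units; within the scatter), so compound 1 stands level with its only measured neighbour. Compound 3 (`CCOC(=O)C(C)S/C(=N/NC(=O)COc1ccc2c(-c3ccccc3)cc(=O)oc2c1)NC`) is still to be measured in this assay. Its difference from compound 1 is methyl in place of acetyl on a saturated chain carbon bound to a carbonyl carbon and a sulfur. The measured step is methyl in place of hydrogen on a saturated chain carbon bound to an amine nitrogen. Among the measured compounds shown here, it does not involve the acetyl, so it bears on this change only weakly and the data hold no direct precedent. No step beyond the scatter is expected, in either direction, and the expected step is a 1.1-fold higher number from compound 1 to compound 3 (0.06 log units; within the scatter). Compound 3 is estimated at 35 ug/mL, with an expected range of 15 ug/mL to 80 ug/mL.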

Compound 3, half-maximal inhibitory concentration: 37 ug/mL
For compound 3 the middle estimate is 1.1-fold (0.02 log units) below the measured one, within the range that was stated.
By their numbers in this assay, from the lowest: compounds 1, 3 and 2 (each within the scatter of the next).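

At this place, on a saturated chain carbon bound to a carbonyl carbon and a sulfur, the data now hold a direct measurement: in this assay, methyl in place of acetyl gives a 1.2-fold higher number from compound 1 to compound 3 (0.08 log units; within the scatter). Losing the acetyl, with its double bond and its hydrogen-bond acceptor, therefore produces no step beyond the scatter, so in this pair the number does not depend on which of these two groups is present. No measurement on hand explains this result.

The compounds shown leave open whether any group at this place would move the number beyond the scatter, for instance a carboxylic acid, an amine or a longer chain. They also leave open whether the methyl-for-acetyl result would hold with an ethyl group in place of the methyl on the amine nitrogen.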